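This account rests on a few compounds, and the source may have more. Where it says the series, first, only, none or still open, it means among the compounds named here.

Working notes on three measured compounds sharing one core, read in a functional assay on DU-145 cells (Homo sapiens) for cytotoxicity, read by sulforhodamine B assay, with a stated time of 48 h; on this read-out higher numbers stand for weaker inhibition and lower numbers for stronger inhibition. Compound 1 (`COc1ccc(C2=NO[C@]3(C2)C(=O)O[C@@H]2[C@H]3CC[C@H](C)[C@]3(O)C=CC(=O)[C@@]23C)cc1`) gives 20000 nM, compound 2 (`C[C@H]1CC[C@@H]2[C@@H](OC(=O)[C@]23CC(c2ccc(Cl)cc2)=NO3)[C@]2(C)C(=O)C=C[C@@]12O`) gives 43000 nM, and compound 3 (`C[C@H]1CC[C@@H]2[C@@H](OC(=O)[C@]23CC(c2ccccc2Br)=NO3)[C@]2(C)C(=O)C=C[C@@]12O`) gives 18000 nM. Compound 3 stands at the low end of these numbers, but not alone: a 1.1-fold lower number from compound 1 to compound 3 (0.05 log units; within the scatter) stays within the scatter, while a 2.4-fold lower number from compound 2 to compound 3 (0.38 log units; beyond the scatter) lies beyond it and is modest.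

Compound 4 (`C[C@H]1CC[C@@H]2[C@@H](OC(=O)[C@]23CC(c2ccccc2[N+](=O)[O-])=NO3)[C@]2(C)C(=O)C=C[C@@]12O`) has nitro in place of bromo on an aromatic carbon, ortho to a large group: nitro in place of bromo on an aromatic carbon.

Within the data shown here, no measured step makes this exact exchange, so the evidence is indirect and comes from the other changes on the same aromatic ring. Besides the two steps above, a 2.2-fold higher number from compound 1 to compound 2 (0.33 log units; beyond the scatter) is also modest. Every aryl change so far has therefore been small, and none of them shows what a nitro group does. From the compounds shown here alone, on that basis, no step beyond the scatter is expected in this assay, and the direction remains open, with only a slight lean toward the higher numbers seen for compound 2 at 43000 nM. The estimate is a 1.3-fold higher number from compound 3 to compound 4 (0.12 log units; within the scatter). For compound 4 the expected value is 24000 nM, with an estimated range from 9000 nM to 60000 nM.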

Compound 4, half-maximal inhibitory concentration: 34000 nM
Compound 4: middle estimate off by 1.4-fold (0.15 log units), on the low side, within the range that was stated.
By their numbers in this assay, from the lowest: compounds 3, 1, 4 and 2 (each within the scatter of the next, the first and the last beyond it).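

In this assay, the exchange of bromo for nitro on an aromatic carbon, ortho to a large group, now has a direct reading in a 1.9-fold higher number from compound 3 to compound 4 (0.28 log units; within the scatter), so this position accepts a larger group of more heavy atoms, carrying hydrogen-bond acceptors that bromo lacks, without a step beyond the scatter. Set against the other two aryl groups, 2-nitrophenyl gives a 1.3-fold lower number from compound 2 to compound 4 (0.10 log units; within the scatter) and a 1.7-fold higher number from compound 1 to compound 4 (0.23 log units; within the scatter), which means compound 4 cannot be separated from any of the three earlier compounds, and the only steps beyond the scatter remain those that the earlier compounds already showed, all of them modest. Nothing at hand accounts for where compound 4 falls in this series.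

From the compounds shown here alone, what an amine or a carboxylic acid would give on this aromatic carbon stays open, and a reading of either would show whether the flat picture across these aryl groups extends to groups that carry a charge. Also open, going by these compounds, is how a nitro group elsewhere on the same ring would read, and whether any of these small steps would hold on cells other than those of this single assay.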